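A few compounds are considered here, and "the series" means these few. Any claim that something is new, unique, unknown or untested is made for them only; others in the source may bear on it.

Within the data shown here, only two compounds have been measured so far in a functional assay on A549 cells (Homo sapiens) for antiproliferative activity, read by MTT assay, with a stated time of 48 h; a lower number here means a stronger inhibitor, a higher number a weaker inhibitor. Compound 1 `COc1cc(-c2nnc(-c3cn4ccccc4n3)o2)cc(OC)c1OC` gives 2800 nM, while compound 2 `Cc1cccn2cc(-c3nnc(-c4ccccc4I)o3)nc12` gives 33400 nM. Compound 1 therefore holds the lower number of the pair and is the stronger inhibitor, by a gap beyond the usual scatter of repeat measurements.

The next compound to be tested is compound 3 `COc1cc(-c2nnc(-c3cn4cccc(C)c4n3)o2)cc(OC)c1OC`, which is compound 1 with one small change: a methyl in place of hydrogen on an aromatic carbon. The methyl sits on a six-membered aromatic ring with 1 nitrogen, part of a fused system of two rings, two atoms from the ring nitrogen.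

Among the measured compounds shown here, no measured pair differs in just one place, so the data give no direct guide to what this change does. Compounds 1 and 2 differ in more than one place, so their gap cannot be credited to any single group. With so small a change, the expectation is no shift beyond the scatter, with a slight lean towards weaker inhibition.

The expected result is a 1.3-fold higher number from compound 1 to compound 3 (0.10 log units; within the scatter). For compound 3 the estimated value is 3500 nM, with an expected range of 1200 nM to 10000 nM.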

Compound 3, half-maximal inhibitory concentration: 9900 nM
Estimate against measurement, compound 3: 2.8-fold (0.45 log units) below, and the stated range covers the measured number.
By their numbers in this assay, from the lowest: compound 1; then compound 3; then compound 2.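

Among these compounds, this is the first comparison in the set that isolates a single change: in this assay, a methyl in place of hydrogen on an aromatic carbon gives a 3.5-fold higher number from compound 1 to compound 3 (0.55 log units; beyond the scatter) and leaves the rest of the molecule untouched. It shows that this position, on the six-membered aromatic ring with 1 nitrogen and two atoms from the ring nitrogen, is not indifferent to substitution, since adding one carbon atom here yields a weaker inhibitor by a modest step that lies beyond the scatter. The data shown offer no measurement that explains why this methyl weakens inhibition.

From the compounds shown here alone, a single comparison at a single carbon cannot say whether any added group here would weaken inhibition or whether this result is particular to methyl, so it remains open how a fluorine, a methoxy or an amine on this same carbon would compare. Going by these compounds, it also remains open whether a methyl on a different carbon of this ring would give a similar step, or a step in the opposite direction.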